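This account rests on a few compounds, and the source may have more. Where it says the series, first, only, none or still open, it means among the compounds named here.

Measured compounds

Compound 1 `COc1ccc(C(C)N(Cc2ccc(C(C)(C)C)cc2)Cc2cc3cc(C)ccc3[nH]c2=O)cc1` gives > 5000 nM in a toxicity assay on MDCK cells (Canis lupus familiaris) for cytotoxicity, read by crystal violet staining, with a stated time of 48 h; a lower number here means that less compound is tolerated, a higher number that more compound is tolerated; this value is a limit of the assay, not a number.
Compound 2 `CCc1ccc2[nH]c(=O)c(CN(Cc3ccc(C(C)(C)C)cc3)C(C)c3ccc(OC)cc3)cc2c1` gives > 5000 nM in this assay; this too is a limit, not a number.
Compound 3 `Cc1ccc2[nH]c(=O)c(CN(Cc3ccc(C(C)(C)C)cc3)C(C)c3ccc(OC(F)F)cc3)cc2c1` gives > 5000 nM in this assay; again a limit, not a number.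

Notes

All three measured values sit at the same limit, (the limit of > 5000 nM in this assay, at which 3 of the 3 values shown sit). The step from compound 1 to compound 2, a step that the two limits leave unreadable from compound 1 to compound 2, therefore cannot be read; the change that makes it is methyl in place of hydrogen on a saturated chain carbon bound to an aromatic carbon. The cores of compound 1 and compound 3 differ by difluoromethyl in place of methyl on an oxygen on an aromatic ring, and the step that the two limits leave unreadable from compound 1 to compound 3 is likewise not readable, both values being limits.

Compound 4 `CCc1ccc2[nH]c(=O)c(CN(Cc3ccc(C(C)(C)C)cc3)C(C)c3ccc(OC(F)F)cc3)cc2c1` has not yet been measured in this assay. Going by the values given here, it differs from compound 3 by methyl in place of hydrogen on a saturated chain carbon bound to an aromatic carbon, which is the same change as the one from compound 1 to compound 2, at the same place. That earlier change left the reading at the limit in both compound 1 and compound 2, and compound 3 already sits at the limit, so the expected step from compound 3 to compound 4 is estimated as a step that the limit leaves unreadable from compound 3 to compound 4. Compound 4 is accordingly expected to give about 8000 nM in this assay, estimated to fall between 4000 nM and 20000 nM, with a good chance that only a limit is again reported.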

Compound 4, half-maximal cytotoxic concentration: > 5000 nM
Compound 4: only a limit was reported; the forecaster's own chance of this, stated with the estimate: 80%; the middle value does not contradict the limit.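

In this assay compound 4 gives > 5000 nM, again a limit and not a number. The steps to compound 4 from compound 2 and from compound 3 cannot be read, since both ends of each are limits: the limit of > 5000 nM in this assay, at which 4 of the 4 values shown sit.

The compounds shown leave open where the tolerated concentration of compound 1, compound 2, compound 3 or compound 4 lies, and whether either change shifts it at all.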